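A Tetrazole in Place of Hydrogen on the Shared Core

This account rests on a few compounds, and the source may have more. Where it says the series, first, only, none or still open, it means among the compounds named here.

In an assay on cells for binding affinity to Myc proto-oncogene protein (Homo sapiens) (a higher number here means a weaker inhibitor, a lower number a stronger inhibitor), compound 2 `N#Cc1ccc(-c2cc(-c3ccccc3)cc(-c3ccco3)n2)cc1` gives 5000 nM, the highest of the two numbers shown. Where compound 2 has hydrogen, carbamoyl is carried by compound 1 `N#Cc1ccc(-c2cc(-c3ccc(C(N)=O)cc3)cc(-c3ccco3)n2)cc1`, which gives 3000 nM, so the step of a 1.7-fold higher number from compound 1 to compound 2 (0.22 log units; within the scatter) is small. Compound 3 `c1coc(-c2cc(-c3nccs3)cc(-c3ccc(-c4nccs4)cc3)n2)c1` shows only a limit, > 100000 nM, in this assay. Compound 4 `N#Cc1ccc(-c2cc(-c3ccc(-c4nnn[nH]4)cc3)cc(-c3ccco3)n2)cc1` differs from compound 2 by 1H-tetrazol-5-yl in place of hydrogen on an aromatic carbon. For the measured compounds named here, the only measured step that bears on this change is a 1.7-fold higher number from compound 1 to compound 2 (0.22 log units; within the scatter), a substituent in place of hydrogen on an aromatic carbon, which stayed within the scatter. For compound 4 the expected step is therefore a 1.7-fold lower number from compound 2 to compound 4 (0.22 log units; within the scatter), nothing beyond the scatter. Compound 4 is thus estimated at 3000 nM, with a range from 900 nM to 10000 nM.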

Compound 4, half-maximal inhibitory concentration: 2000 nM
For compound 4 the middle estimate is 1.5-fold (0.18 log units) above the measured one, within the range that was stated.
By their numbers in this assay, from the lowest: compounds 4, 1 and 2 (each within the scatter of the next, the first and the last beyond it). At a limit, above all of these: compound 3.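

In this assay, for the compounds shown here, 1H-tetrazol-5-yl in place of hydrogen, para to a large group, gives a 2.5-fold lower number from compound 2 to compound 4 (0.40 log units; beyond the scatter) and so provides the first step at this position that lies beyond the scatter, though it is modest. Against carbamoyl at the same place, it gives a 1.5-fold lower number from compound 1 to compound 4 (0.18 log units; within the scatter) and cannot be told apart from that group. Only the tetrazole, however, stands clear of hydrogen.

As far as these compounds go, whether a carboxylic acid, an amine or a longer chain at this position would lower the number further remains open. Nothing shown here accounts for the step.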